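The source may report more compounds than this note shows. Statements on the series, on what has been measured and on what is new or still open speak of the compounds shown alone.

Measured so far:
compound 1 `O=[N+]([O-])c1ccc(NC(=S)Nc2cccc(C(F)(F)F)c2)cc1`: 9500 nM
compound 2 `CCCC[C@H]1CC[C@H](c2ccc(NC(=S)Nc3cccc(C(F)(F)F)c3)cc2)CC1`: 9500 nM
compound 3 `Fc1ccc(NC(=S)Nc2cccc(C(F)(F)F)c2)cc1`: 26000 nM

In an ADME assay on BHK cells (Mesocricetus auratus) for cytotoxicity, read by MTT assay, with a stated time of 96 h (on this read-out higher numbers stand for lower toxicity in this test and lower numbers for higher toxicity in this test), compound 3 holds the highest of the three numbers, 26000 nM, which makes it the least toxic of the three in this test. The other two do not separate, with no change at the digits printed from compound 1 to compound 2 (within the scatter). Compound 3 stands apart from both, with a 2.7-fold higher number from compound 1 to compound 3 (0.44 log units; beyond the scatter) and a 2.7-fold higher number from compound 2 to compound 3 (0.44 log units; beyond the scatter).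

The next compound is compound 4 `Fc1cccc(NC(=S)Nc2cccc(C(F)(F)F)c2)c1`, which has the same atoms as compound 3, joined differently. In it, 3-fluorophenyl takes the place of 4-fluorophenyl on an amide-type nitrogen (3-fluorophenyl in place of 4-fluorophenyl on an amide-type nitrogen).

Going by the values given here, no measured step is a direct precedent for this change, since each one replaces a group with a different group, whereas here the fluoro group is kept and only its place changes. They still offer a rough guide: the steps between these quite different groups reach only a modest size, as in a 2.7-fold higher number from compound 2 to compound 3 (0.44 log units; beyond the scatter). A smaller change is therefore expected here, with no preferred direction and nothing beyond the scatter. The expected change is a 1.2-fold lower number from compound 3 to compound 4 (0.07 log units; within the scatter). For compound 4 the estimated value is 22000 nM, with an expected range from 10000 nM to 48000 nM.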

Compound 4, half-maximal cytotoxic concentration: 9400 nM
Estimate against measurement, compound 4: 2.3-fold (0.37 log units) above; the whole stated range lies above it.
By their numbers in this assay, from the lowest: compounds 4, 1 and 2 (each within the scatter of the next); then compound 3.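

In this assay moving the fluoro alone, with no atom gained or lost, gives a 2.8-fold lower number from compound 3 to compound 4 (0.44 log units; beyond the scatter) and so shows that 3-fluorophenyl and 4-fluorophenyl on the amide-type nitrogen are not interchangeable in this test. Going by these compounds alone, the size is much the same as for the step that put fluoro in place of nitro (a 2.7-fold higher number from compound 1 to compound 3 (0.44 log units; beyond the scatter)), so a change of place alone can count here for as much as a change of group, which the earlier steps, each swapping one group for another, could not show. The higher number of compound 3 therefore goes with 4-fluorophenyl as a whole and not with the mere presence of a fluoro, and nothing given here explains why the place matters.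

The compounds shown leave open whether this sensitivity to place belongs to fluoro alone or would also appear with a chloro or a methoxy group in its stead. They also leave open whether an amine or a carboxylic acid on the same ring would move the number further in either direction.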